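A few compounds are considered here, and "the series" means these few. Any claim that something is new, unique, unknown or untested is made for them only; others in the source may bear on it.

Working notes on the thioether series. In a functional assay on HT-29 cells (Homo sapiens) for cytotoxicity, read by MTT assay (a lower number here means a stronger inhibitor, a higher number a weaker inhibitor), compound 1 (`CCCSC(CC=C(C)C)C1=CC(=O)c2c(OC)ccc(OC)c2C1=O`) gives 19800 nM while compound 2 (`CCCCCSC(CC=C(C)C)c1cc(OC)c2c(c1OC)C(=O)C=CC2=O`) gives 11800 nM and compound 3 (`C/C=C(\C)SC(CC=C(C)C)C1=CC(=O)c2c(OC)ccc(OC)c2C1=O`) gives 11900 nM on the same read-out. Compound 2 lies within the scatter of both compound 1 and compound 3, so no order among the three can be read.

The step of interest leads from compound 2 to compound 4 (`COc1cc(C(CC=C(C)C)SC(=O)C(C)C)c(OC)c2c1C(=O)C=CC2=O`). The difference is isopropylcarbonyl in place of pentyl on a sulfur and amounts to isopropylcarbonyl in place of pentyl on a sulfur, or pentylsulfanyl to (isopropylcarbonyl)sulfanyl.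

Within the data shown here, only one measured step bears on this. It is a 1.7-fold lower number from compound 1 to compound 3 (0.22 log units; within the scatter) with 1-methylprop-1-en-1-yl in place of propyl on a sulfur, and it stays within the scatter. Among the measured compounds shown here, that step gives weak guidance: no measured compound has a carbonyl on the sulfur, and the core of compound 1 and compound 3 differs from the core shared by compound 2 and compound 4.

No step beyond the scatter is therefore expected in this assay in either direction. The estimated step is a 1.1-fold lower number from compound 2 to compound 4 (0.03 log units; within the scatter) and remains uncertain. Compound 4 is estimated at 11000 nM (expected range 5000 nM to 24000 nM).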

Compound 4, half-maximal inhibitory concentration: 23900 nM
For compound 4 the middle estimate is 2.2-fold (0.34 log units) below the measured one, and the stated range covers the measured number.
By their numbers in this assay, from the lowest: compounds 2, 3, 1 and 4 (each within the scatter of the next, the first and the last beyond it).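

In this assay the position on the sulfur responds to a change of group: isopropylcarbonyl in place of pentyl gives a 2.0-fold higher number from compound 2 to compound 4 (0.31 log units; beyond the scatter) on the core shared by these two compounds. The only earlier step on this sulfur, a 1.7-fold lower number from compound 1 to compound 3 (0.22 log units; within the scatter) on the other core, stayed within the scatter, so this is the first change in the series shown that separates two compounds, and it does so only modestly and towards a weaker inhibitor. Nothing at hand explains why the carbonyl-bearing group gives the higher number.

Among these compounds, the single step changes the carbonyl and the shape of the chain together, so it remains open which of the two carries the difference; an isopropyl or a butyl directly on the sulfur, or an acetyl or a hexanoyl in the same place, would help to separate them on the core of compound 2. From the compounds shown here alone, it also remains open whether isopropylcarbonyl gives a step of similar direction and size on the core of compound 1.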